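The compounds below may be only part of what the source reports. "The series", "measured", "known", "first", "only" and "open" are said of these compounds alone.

In an assay on HEK293 cells for antagonist activity at transient receptor potential cation channel subfamily V member 1 (Rattus norvegicus), read by fluorescence and calcium flux (a lower number here means a stronger inhibitor, a higher number a weaker inhibitor), compound 2 `COc1cccc(N(C)C(=O)/C=C/c2ccc(Cl)cc2)c1` gives 1300 nM. On the numbers shown it stands beside compound 1 `CN(C(=O)/C=C/c1ccc(Cl)cc1)c1cccc(OCCCF)c1`, which in this assay gives 1100 nM, the two values lying within the scatter of each other. Compound 3 `CN(C(=O)/C=C/c1ccc(Cl)cc1)c1cccc(OCCF)c1` has not yet been measured in this assay; it differs from compound 2 by fluoromethyl in place of hydrogen on a saturated chain carbon bound to an oxygen on an aromatic ring, a change that, cut one bond further out, reads methyl to 2-fluoroethyl, or methoxy to 2-fluoroethoxy. For the measured compounds named here, one measured step bears on it: a 1.2-fold higher number from compound 1 to compound 2 (0.07 log units; within the scatter), in which a 2-fluoroethyl group on a saturated chain carbon bound to an oxygen on an aromatic ring gave way to hydrogen without moving the number beyond the scatter. Compound 3 carries a fluoromethyl group at that same place, a chain between those of compound 1 and compound 2 in length. For compound 3 the expected step from compound 2 is therefore a 1.2-fold lower number from compound 2 to compound 3 (0.07 log units; within the scatter), that is, no shift beyond the scatter, because a 1.2-fold higher number from compound 1 to compound 2 (0.07 log units; within the scatter) was itself within the scatter. The estimate for compound 3 in this assay is accordingly 1100 nM, with a range from 500 nM to 2500 nM.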

Compound 3, half-maximal inhibitory concentration: 4200 nM
Beside the measured number, compound 3's estimate is 3.8-fold (0.58 log units) below it, outside the stated range (above it).
By their numbers in this assay, from the lowest: compounds 1 and 2 (each within the scatter of the next); then compound 3.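

In this assay, the place on a saturated chain carbon bound to an oxygen on an aromatic ring proves sensitive to what stands there, as fluoromethyl in place of hydrogen gives a 3.2-fold higher number from compound 2 to compound 3 (0.51 log units; beyond the scatter) even though the earlier step between the other two compounds stayed within the scatter. Replacing fluoromethyl with fluoro at the saturated chain carbon, two bonds along the chain from that oxygen, gives a 3.8-fold higher number from compound 1 to compound 3 (0.58 log units; beyond the scatter) and so leaves compound 3 as the weakest inhibitor of the three, while the methoxy group of compound 2 and the longer fluorinated chain of compound 1 lie within the scatter of each other, so the number does not follow chain length in a single direction. Nothing available accounts for why the 2-fluoroethoxy group stands apart.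

The compounds shown leave open whether the rise belongs to the fluorine or to the chain itself, a question that a plain ethoxy or propoxy group would address. They also do not show how this place would respond to a hydroxyl, an amine or a carboxylic acid at the chain end, or to a still longer chain.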